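The compounds below may be only part of what the source reports. "The series", "measured", "known", "first", "only" and "open" are said of these compounds alone.

Measured in a functional assay on NCI-H23 cells (Homo sapiens) for inhibition, read by ELISA, with a stated time of 24 h; a higher number here means a weaker inhibitor of growth, a lower number a stronger inhibitor of growth:
- Compound 1 `CC(=O)ONC(=O)/C=C/c1ccccc1OC(=O)c1ccccc1`: 26300 nM
- Compound 2 `O=C(/C=C/c1ccccc1OC(=O)c1ccccc1)NOC(=O)N1CCOCC1`: 12900 nM

Of these two, compound 2 has the lower number, which makes it the stronger inhibitor of growth so far. The unmeasured compound 3 `O=C(/C=C/c1ccccc1OC(=O)c1ccccc1)NOC(=O)c1ccccc1` differs from it at one place: phenyl in place of morpholin-4-yl on a carbonyl carbon. Going by the values given here, only one measured step bears on this carbonyl carbon: a 2.0-fold lower number from compound 1 to compound 2 (0.31 log units; beyond the scatter). That step, with morpholin-4-yl in place of methyl, was modest though beyond the scatter. A single step shows no trend and says nothing direct about phenyl, so no firm direction can be expected in this assay, and a change of similar modest size or none beyond the scatter seems most likely. The estimated change is a 1.1-fold higher number from compound 2 to compound 3 (0.04 log units; within the scatter). The expected value for compound 3 is 14000 nM, within an estimated range of 6000 nM to 32000 nM.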

Compound 3, concentration for 50% growth inhibition: 18200 nM
Estimate against measurement, compound 3: 1.3-fold (0.11 log units) below, within the range that was stated.
By their numbers in this assay, from the lowest: compounds 2, 3 and 1 (each within the scatter of the next, the first and the last beyond it).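

In this assay, a third group on this carbonyl carbon can now be compared, and phenyl lies within the scatter of both other groups (a 1.4-fold higher number from compound 2 to compound 3 (0.15 log units; within the scatter)) (a 1.4-fold lower number from compound 1 to compound 3 (0.16 log units; within the scatter)). Replacing morpholin-4-yl, a non-aromatic ring with 2 hetero atoms, with phenyl, an aromatic ring of carbon only, gives no readable change here, so phenyl cannot be ordered against either methyl or morpholin-4-yl, even though those two lie beyond the scatter of each other. No available information accounts for the values of these three groups.

The compounds shown leave open whether an open-chain amine such as dimethylamino or a longer carbon chain such as butyl on this carbonyl carbon would stand clearly apart from these three. They also leave open whether a carboxylic acid added to the phenyl ring would shift the number beyond the scatter.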